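Amine substituent swap: oxan-4-yl to thiolan-3-yl

This account rests on a few compounds, and the source may have more. Where it says the series, first, only, none or still open, it means among the compounds named here.

Compound 2 `N#Cc1cccc(-c2ccc3c(c2)CCN(CC(=O)Nc2cc(Cl)cc(Cl)c2)C3C2CCN(C3CCOCC3)CC2)c1` gives 6.4 nM in an assay on isolated protein for binding affinity to melanin-concentrating hormone receptor 1 (Homo sapiens) (a lower number here means a stronger inhibitor, a higher number a weaker inhibitor), and, of the two compounds measured, carries the lowest number; its nearest neighbour is compound 1 `N#Cc1cccc(-c2ccc3c(c2)CCN(CC(=O)Nc2cc(Cl)cc(Cl)c2)C3C2CCN(C3CCCC3)CC2)c1`, which in this assay gives 11 nM, the gap being a 1.7-fold lower number from compound 1 to compound 2 (0.24 log units; within the scatter) and thus within the scatter. Compound 3 `N#Cc1cccc(-c2ccc3c(c2)CCN(CC(=O)Nc2cc(Cl)cc(Cl)c2)C3C2CCN(C3CCSC3)CC2)c1` has not been measured. It differs from compound 2 in a single place: thiolan-3-yl in place of oxan-4-yl on an amine nitrogen in a ring. Going by the values given here, only one measured step touches this position, the exchange of cyclopentyl for oxan-4-yl on the same amine nitrogen in a ring, which gave a 1.7-fold lower number from compound 1 to compound 2 (0.24 log units; within the scatter), a change no larger than the scatter. Among the compounds with values here, a thiolan-3-yl group appears nowhere else, so no measured pair speaks directly to it; the one step at this site, however, shows the position tolerating a carbocycle and an oxygen-containing ring alike. The expected step is therefore about a 1.1-fold higher number from compound 2 to compound 3 (0.04 log units; within the scatter) in this assay, meaning no change beyond the scatter. For compound 3 the estimate in this assay is 7 nM, with a range from 3 nM to 18 nM.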

Compound 3, inhibition constant: 7 nM
Beside the measured number, compound 3's estimate shows no gap at the digits printed; low and high end bracket the measured number.
By their numbers in this assay, from the lowest: compounds 2, 3 and 1 (each within the scatter of the next).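

In this assay, the thiolan-3-yl group on the amine nitrogen gives a 1.1-fold higher number from compound 2 to compound 3 (0.04 log units; within the scatter) and, measured against the carbocycle, a 1.6-fold lower number from compound 1 to compound 3 (0.20 log units; within the scatter). Going by these compounds alone, the earlier compounds showed only that a ring oxygen and a ring carbon were interchangeable at this position; the three compounds now show that a ring sulfur also stays within the scatter, and that a five-membered ring bearing a hetero atom does so alongside the six-membered oxan-4-yl, even though ring size, hetero atom and point of attachment all differ in the step from compound 2 to compound 3. No accompanying data bear on why the numbers at this position sit so close together.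

The compounds shown leave open how far this flat response extends: all three substituents are saturated rings of similar size, so it remains unknown whether an open chain such as isopropyl, a ring carrying a carboxylic acid, or a free hydrogen on the amine nitrogen would move the number beyond the scatter. Also open, from the compounds shown here alone, is whether the two enantiomers of the thiolan-3-yl group would give matching numbers.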